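The source may report more compounds than this note shows. Statements on the series, on what has been measured and on what is new or still open speak of the compounds shown alone.

Measured in an ADME assay on BaF3 cells (Mus musculus) for cytotoxicity (a lower number here means that less compound is needed, a higher number that more compound is needed for the effect), so far:
- Compound 1 `Nc1nc2ccc(-c3cccc(C(=O)Nc4cccc(C(F)(F)F)c4)c3)nc2s1` gives > 10000 nM (a limit)
- Compound 2 `CC(=O)Nc1nc2ccc(-c3cccc(C(=O)Nc4cccc(C(F)(F)F)c4)c3)nc2s1` gives > 10000 nM (a limit)

Compound 2 stands at > 10000 nM in this assay and this reading is a limit, not a number. Compound 3 `O=C(Nc1cccc(C(F)(F)F)c1)c1cccc(-c2ccc3nc(NC(=O)C4CC4)sc3n2)c1` differs from it by cyclopropyl in place of methyl on a carbonyl carbon (cyclopropyl in place of methyl on a carbonyl carbon, or acetyl to cyclopropylcarbonyl). For the measured compounds named here, the only measured step that bears on this change is a step that the two limits leave unreadable from compound 1 to compound 2 and it gives no usable size. Compound 1 and compound 2 share the limit of > 10000 nM in this assay, at which 2 of the 2 values shown sit, as the whole of the evidence. No step beyond the scatter is therefore expected in this assay for this change. The expected step runs a number no higher from compound 2 to compound 3 (the limit leaves the size open) and carries no expected direction. Compound 3 is estimated at 10000 nM with an expected range of 3000 nM to 30000 nM and will most likely be reported as a limit again.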

Compound 3, half-maximal effective concentration: 910 nM
Estimate against measurement, compound 3: 11-fold (1.04 log units) above; the whole stated range lies above it.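

In this assay, cyclopropyl in place of methyl on the carbonyl carbon gives an at least 10-fold lower number from compound 2 to compound 3 (1.04 log units; beyond the scatter), and cyclopropylcarbonyl in place of hydrogen on the aromatic amine nitrogen gives an at least 10-fold lower number from compound 1 to compound 3 (1.04 log units; beyond the scatter). For the compounds shown here, compound 3 is thus the first compound here with a reading that is a number, which shows that the group on this carbonyl carbon can shift the result by more than the scatter. The readings of compound 1 and compound 2 are both limits, and the step between them cannot be read: the limit of > 10000 nM in this assay, at which 2 of the 3 values shown sit.

An isopropyl or cyclobutyl group on this carbonyl carbon would help separate the contribution of the three-membered ring from that of the added carbons. On these data alone, the full size of both steps also stays open, as each starts from a limit.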